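The source may report more compounds than this note shows. Statements on the series, on what has been measured and on what is new or still open speak of the compounds shown alone.

Compound 3, built as `OC(CCn1nc2c(Br)c(Br)c(Br)c(Br)c2n1)c1ccc(Br)cc1`, is the reference point here. In a functional assay on CCRF-CEM cells (Homo sapiens) for antiproliferative activity, read by MTT assay, with a stated time of 24 h, tested at 100 uM (on this read-out lower numbers stand for a stronger effect and higher numbers for a weaker effect at the one concentration tested), compound 3 gives 0%, level with compound 1 at the digits shown, and the two together stand as the lowest of the three numbers seen so far. Compound 1, built as `OC(CCn1nc2c(Br)c(Br)c(Br)c(Br)c2n1)c1cccc(Cl)c1`, gives 0% in this assay, and the step of no change at the digits printed from compound 1 to compound 3 (within the scatter) is within the scatter. Compound 2, built as `C[C@H](O)CCn1nc2c(Br)c(Br)c(Br)c(Br)c2n1`, gives 36% in this assay, so its value and that of compound 3 lie apart by more than the scatter.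

Compound 4, built as `CC(O)CCn1nc2c(Br)c(Br)c(Br)c(Br)c2n1`, has not yet been measured. The change from compound 3 to compound 4 is methyl in place of 4-bromophenyl on a saturated chain carbon bound to an oxygen on a saturated carbon and a saturated chain carbon. Going by the values given here, no measured step covers exactly this exchange; the only measured step concerns the swap of one aryl group for another and was flat. What bears on it is that compound 2 carries a methyl in the same place and gives 36%, whereas the two aryl-bearing compounds stand lower: compound 1 gives 0% and compound 3 gives 0%.

On that basis compound 4 is expected to move by a number 36 percentage points higher from compound 3 to compound 4 (beyond the scatter), and the estimate for compound 4 in this assay is 36%, with a range from 15% to 60%.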

Compound 4, a percentage reported as activity, at one concentration (the size of the read-out at that concentration, not a potency): 3%
Beside the measured number, compound 4's estimate is 33 percentage points above it; measured number outside the range, below it.
By their numbers in this assay, from the lowest: compounds 1, 3 and 4 (each within the scatter of the next); then compound 2.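

In this assay, putting methyl in place of an aryl group on this saturated chain carbon does not by itself separate the compounds: the record shows a number 3 percentage points higher from compound 3 to compound 4 (within the scatter) and a number 3 percentage points higher from compound 1 to compound 4 (within the scatter). Going by these compounds alone, the aryl group is therefore not required for a low number at this position, and the earlier link between methyl and a higher number rested on compound 2 alone, which now stands as the one compound against the pattern of methyl and aryl compounds reading alike. Compound 2 and compound 4 differ sharply, with a number 33 percentage points lower from compound 2 to compound 4 (beyond the scatter), and the only difference the structures show at this position is a matter of how the stereocentre is drawn: the fact that one of compounds 2 and 4 is drawn with a defined configuration and the other without, at the place where they differ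

Going by these compounds, whether the opposite configuration of the stereocentre would read with compound 2 or with compound 4 stays open, so the data cannot yet tie the large step to one defined form. Also open, on these data alone, is how an amine, a carboxylic acid or a longer chain would read on this carbon in place of methyl or the aryl groups.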